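This account rests on a few compounds, and the source may have more. Where it says the series, first, only, none or still open, it means among the compounds named here.

Measured in a functional assay on HCT-116 cells (Homo sapiens) for inhibition, read by MTT assay, with a stated time of 48 h (a higher number here means a weaker inhibitor, a lower number a stronger inhibitor), so far:
- Compound 1 `COc1ccc(-n2c(SCc3ccc(F)cc3)nnc2-c2cc(OC)c(OC)c(OC)c2)cc1` gives 38700 nM
- Compound 2 `CCOC(=O)CSc1nnc(-c2cc(OC)c(OC)c(OC)c2)n1-c1ccc(OC)cc1` gives > 60000 nM as a limit
- Compound 3 `COc1cc(-c2nnc(S)n2-c2ccc(N(C)C)cc2)cc(OC)c1OC` gives > 60000 nM as a limit

Compound 3 stands at > 60000 nM as a limit, not a number. That reading is the limit of > 60000 nM in this assay, at which 2 of the 3 values shown sit, and no more is known of compound 3.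

Compound 4 `COc1cc(-c2nnc(SCC(=O)c3ccccc3)n2-c2ccc(N(C)C)cc2)cc(OC)c1OC` has benzoylmethyl in place of hydrogen on a sulfur. Among the measured compounds shown here, one measured step bears on this, and only indirectly (an at least 1.5-fold higher number from compound 1 to compound 2 (0.19 log units; that floor lies within the scatter)). It puts ethoxycarbonyl in place of 4-fluorophenyl on a saturated chain carbon bound to a sulfur, and its floor lies within the scatter.

The closest guide is compound 1, which carries 4-fluorophenyl on that chain and reads 38700 nM as a measured number. Compound 2, also substituted on sulfur, stays at > 60000 nM as a limit, which goes against any rule.

A small move toward a lower number is therefore expected in this assay, perhaps no larger than the scatter. The expected step is an at least 1.5-fold lower number from compound 3 to compound 4 (0.17 log units; that floor lies within the scatter) and the reading may again be a limit. For compound 4 the estimated value is 40000 nM (expected range 15000 nM to 100000 nM).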

Compound 4, half-maximal inhibitory concentration: 42500 nM
Beside the measured number, compound 4's estimate is 1.1-fold (0.03 log units) below it; the measured number falls inside the stated range.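

In this assay, the change on the sulfur gives an at least 1.4-fold lower number from compound 3 to compound 4 (0.14 log units; that floor lies within the scatter). The true size of this step cannot be told, and it remains only a floor, because compound 3 is held at a limit and not a number: the limit of > 60000 nM in this assay, at which 2 of the 4 values shown sit. What the pair adds is the first step shown that starts from the free sulfanyl: going from sulfanyl to (benzoylmethyl)sulfanyl on this core leads to compound 4, which gives a measured 42500 nM and not a limit.

The compounds shown do not separate the carbonyl of the benzoylmethyl group from its aromatic ring as the part that matters for this reading. Also open, from the compounds shown here alone, is how a simple methyl, a benzyl or a carboxylic acid chain on the same sulfur of this core would read in this assay.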